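Compound 2 to compound 4: a methyl on the acid chain

The compounds below may be only part of what the source reports. "The series", "measured", "known", "first", "only" and "open" are said of these compounds alone.

In an ADME assay on microsomes from liver (Homo sapiens) for metabolic stability (on this read-out higher numbers stand for fast clearance and lower numbers for slow clearance), compound 2 `O=C(O)Cn1nc(Cn2cc3cc(OCC4CC4)c(Cl)cc3n2)c2ccccc2c1=O` gives only a limit (< 25 mL/min/kg). Compound 1 `O=C(O)Cn1nc(Cc2cn3cc(OCC4CC4)c(Cl)cc3n2)c2ccccc2c1=O` also gives only a limit (< 16.7 mL/min/kg). Compound 3 `O=C(O)Cc1nn(Cc2cn3cc(OCC4CC4)c(Cl)cc3n2)c2ccccc2c1=O` is the only one of the three with a number (18.3 mL/min/kg). The position of compound 2 is therefore known only through its limit, and no order among the three can be read from these results.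

Compound 4 `C[C@H](C(=O)O)n1nc(Cn2cc3cc(OCC4CC4)c(Cl)cc3n2)c2ccccc2c1=O` differs from compound 2 by methyl in place of hydrogen on a saturated chain carbon bound to an aromatic nitrogen and a carbonyl carbon. This is methyl in place of hydrogen on a saturated chain carbon bound to an aromatic nitrogen and a carbonyl carbon, which turns carboxymethyl into 1-carboxyethyl. Going by the values given here, no measured pair isolates this change, so neither a size nor a direction can be taken from the data. The expectation is no shift beyond the scatter, and the estimated step that the limit leaves unreadable from compound 2 to compound 4 fits that reading. The number for compound 3 (18.3 mL/min/kg) serves as the nearest numerical anchor.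

For compound 4 the estimated clearance is 20 mL/min/kg (expected range 11 mL/min/kg to 36 mL/min/kg).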

Compound 4, clearance: 20 mL/min/kg
Compound 4: the middle estimate sits on the measured number at the digits printed; measured number inside the range.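

In this assay compound 2 gives only a limit, namely < 25 mL/min/kg and no size can be read for the step to compound 4. The compounds shown leave open whether turning carboxymethyl into 1-carboxyethyl shifts clearance at all, and in which direction.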